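Pyrimidine amine series: cyclopentyl to butyl on the ring nitrogen

This account rests on a few compounds, and the source may have more. Where it says the series, first, only, none or still open, it means among the compounds named here.

Measured so far:
compound 1, `O=C(Nc1ncc(-c2cccc(Cl)c2)c(-c2ccccc2)n1)C1CCCC1`: 47%
compound 2, `Clc1cccc(-c2cnc(NC3CCCC3)nc2-c2ccccc2)c1`: > 80%

In an assay on CHO cells for displacement of a labelled ligand from adenosine receptor A1 (Homo sapiens), read by scintillation counting, with a stated time of 1 h, tested at 1 uM (a higher number here means more inhibition at the concentration tested (going by the name of the read-out), a lower number less inhibition), compound 1 gives 47%. Compound 2 is reported only as a limit of the assay, not a number, (the limit of > 80% in this assay, at which 1 of the 2 values shown sits), so it stands at the top of the range seen. Going by the values given here, the single measured step, a number at least 33 percentage points higher from compound 1 to compound 2 (beyond the scatter), concerns cyclopentyl in place of cyclopentylcarbonyl and so does not touch the change considered next.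

Compound 3, `CCCCNc1ncc(-c2cccc(Cl)c2)c(-c2ccccc2)n1`, differs from compound 2 by butyl in place of cyclopentyl on a nitrogen on an aromatic ring. Among the compounds with values here, no measured step bears on this change. The expected step is a number at least 10 percentage points lower from compound 2 to compound 3 (that floor lies within the scatter), small. Compound 3 is therefore estimated at 70%, within 45% to 90%.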

Compound 3, a percentage reported as inhibition, at one concentration (the size of the read-out at that concentration, not a potency): 56%
The estimate for compound 3 lay 14 percentage points above the measured number; the range from low to high includes it.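

In this assay, butyl in place of cyclopentyl on a nitrogen on an aromatic ring gives a number at least 24 percentage points lower from compound 2 to compound 3 (beyond the scatter), so the alkyl group on this nitrogen matters even without a carbonyl. Butyl in place of cyclopentylcarbonyl gives a number 9 percentage points higher from compound 1 to compound 3 (within the scatter), which leaves compound 1 and compound 3 unordered and compound 2 alone apart from both. Compound 2 is held only as a limit, not a number: the limit of > 80% in this assay, at which 1 of the 3 values shown sits.

Still open, on these data alone, is whether the ring or the chain form carries the step. A pentyl chain or a cyclohexyl ring on this nitrogen would bear on that.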